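The source may report more compounds than this note shows. Statements on the series, on what has been measured and on what is new or still open speak of the compounds shown alone.

Measured so far in a functional assay on cells for agonist activity at Free fatty acid receptor 1 (Mus musculus), read by FLIPR and calcium flux, with a stated time of 100 s; a lower number here means that less compound is needed, a higher number that more compound is needed for the effect:

Compound 1, `Cc1cccc(Oc2ccc(N3CCC[C@H]3CC(=O)O)cc2)c1`, gives 2400 nM in this assay.
Compound 2, `O=C(O)C[C@@H]1CCCN1c1ccc(Oc2cccc(Cl)c2)cc1`, gives only a limit of the assay in this assay, > 16000 nM.
Compound 3, `Cc1cccc(Oc2ccc(N3C[C@@H](C(F)(F)F)C[C@H]3CC(=O)O)cc2)c1C`, gives 500 nM in this assay.

Compound 1 and compound 2 share one core and differ in one place, (chloro in place of methyl on an aromatic carbon). That change gives an at least 6.6-fold higher number from compound 1 to compound 2 (0.82 log units; beyond the scatter), a step that rests on the limit (the limit of > 16000 nM in this assay, at which 1 of the 3 values shown sits), so its true size is not known beyond being at least as large as shown.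

Compound 3 differs from compound 1 in more than one place; the difference between the two cores is not broken down here. Compound 3 stands lowest of the two numbers, with compound 1 the nearest at a higher number beyond the scatter.

Compound 4, `Cc1c(Cl)cccc1Oc1ccc(N2C[C@@H](C(F)(F)F)C[C@H]2CC(=O)O)cc1`, is compound 3 with one change, (chloro in place of methyl on an aromatic carbon). The change is the same kind of change as that from compound 1 to compound 2, chloro in place of methyl on an aromatic carbon, but not the same: in compound 4 the site is ortho to a methyl group as well as meta to a large group, while in compound 2 it is only meta to a large group.

On the strength of the measured step of an at least 6.6-fold higher number from compound 1 to compound 2 (0.82 log units; beyond the scatter), the step expected from compound 3 to compound 4 in this assay is an 8.0-fold higher number from compound 3 to compound 4 (0.90 log units; beyond the scatter), a rise in the number. For compound 4 the expected value in this assay is 4000 nM, estimated to lie between 1200 nM and 16000 nM.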

Compound 4, half-maximal effective concentration: 430 nM
For compound 4 the middle estimate is 9.3-fold (0.97 log units) above the measured one, and the stated range ends above it.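

In this assay, putting chloro in place of methyl on the aromatic carbon gives a 1.2-fold lower number from compound 3 to compound 4 (0.07 log units; within the scatter), so on this core the change moves the number by no more than the scatter. Set beside the earlier step, the same change does not carry over unchanged from one core to the other: the same change on two cores in this assay, an at least 6.6-fold higher number (0.82 log units; beyond the scatter) from compound 1 to compound 2 and a 1.2-fold lower number (0.07 log units; within the scatter) from compound 3 to compound 4, at least 7.7-fold (0.88 log units) apart, beyond the scatter of two such steps. The earlier step rests on a limit of the assay, and the two pairs differ both in their cores and at the site itself, which in compound 4 is ortho to a methyl group, so they do not show which of these differences goes with the gap or how the change would read on any further core: the limit of > 16000 nM in this assay, at which 1 of the 4 values shown sits.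

The compounds shown leave open whether the trifluoromethyl group on the core, the methyl group ortho to the site, or both together separate the two outcomes, as compound 3 differs from compound 1 in more than one place. Also open, as far as these compounds go, is how fluoro, methoxy or a nitrile on the same aromatic carbon would read in this assay on either core.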